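Ethyl Ester of Compound 1 in a Cell Toxicity Test

The compounds below may be only part of what the source reports. "The series", "measured", "known", "first", "only" and "open" are said of these compounds alone.

- Compound 1 `COc1cc(OC)c2c(c1)c(C(=O)/C=C(\O)C(=O)O)cn2Cc1ccc(F)cc1` gives 58500 nM here
- Compound 2 `CCOC(=O)/C(O)=C/C(=O)c1cn(Cc2ccc(F)cc2)c2cc(OC)cc(OC)c12` gives 55400 nM here

In an ADME assay on MT4 cells (Homo sapiens) for cytotoxicity, read by MTT assay (on this read-out higher numbers stand for lower toxicity in this test and lower numbers for higher toxicity in this test), compound 1 gives 58500 nM and compound 2 gives 55400 nM so the two stand level within the usual scatter of such measurements.

Compound 3 `CCOC(=O)/C(O)=C/C(=O)c1cn(Cc2ccc(F)cc2)c2c(OC)cc(OC)cc12` still awaits measurement. Compared with compound 1, it carries the change ethyl in place of hydrogen on an oxygen next to a carbonyl group in the form of ethyl in place of hydrogen on an oxygen next to a carbonyl group, so that carboxy becomes ethoxycarbonyl. For the measured compounds named here, no measured pair shows this change alone. Compound 2 also carries ethoxycarbonyl, and its 55400 nM lies within the scatter of compound 1. In this assay no change beyond the scatter is therefore expected, and the estimated step of a 1.2-fold lower number from compound 1 to compound 3 (0.07 log units; within the scatter) remains small. Compound 3 is expected at 50000 nM with a likely range from 20000 nM to 110000 nM for its measurement.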

Compound 3, half-maximal cytotoxic concentration: 62100 nM
Compound 3: middle estimate off by 1.2-fold (0.09 log units), on the low side, and the stated range covers the measured number.
By their numbers in this assay, from the lowest: compounds 2, 1 and 3 (each within the scatter of the next).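

For the compounds shown here, this is the first pair in which carboxy becomes ethoxycarbonyl and nothing else differs, so the change can now be read on its own in this assay (a 1.1-fold higher number from compound 1 to compound 3 (0.03 log units; within the scatter)). On the core of compound 1, ethyl in place of hydrogen on an oxygen next to a carbonyl group therefore leaves the number within the scatter, and this test does not separate the two forms. Nothing available explains this outcome.

The compounds shown leave open whether a longer chain such as butyl, or a ring such as benzyl, on this same oxygen would also stay within the scatter. They also leave open whether an amide in place of the ester would give a number level with compound 1.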